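The compounds below may be only part of what the source reports. "The series", "measured", "known", "first", "only" and "open" are said of these compounds alone.

In a functional assay on PC-3 cells (Homo sapiens) (on this read-out higher numbers stand for weaker inhibition of growth and lower numbers for stronger inhibition of growth), compound 1 `COc1cc2ncnc(Nc3ccc(CS(=O)(=O)/C=C/c4ccc(Cl)cc4Cl)cc3)c2cc1OC` gives 5000 nM. Compound 2 `COc1cc2ncnc(Nc3ccc(CS(=O)(=O)/C=C/c4ccc(F)cc4)cc3)c2cc1OC` gives > 100000 nM, which is a limit of the assay and not a number. Compound 3 `COc1cc2ncnc(Nc3ccc(CS(=O)(=O)/C=C/c4ccc(Br)cc4)cc3)c2cc1OC` differs from compound 2 by bromo in place of fluoro on an aromatic carbon, with bromo in place of fluoro para to a large group. Within the data shown here, the only measured step bearing on this is an at least 20-fold higher number from compound 1 to compound 2 (1.30 log units; beyond the scatter), a large change on the same aryl group. A moderate to large move towards a lower number in this assay is therefore expected, though compound 3 may also stay at the limit. The expected step is an at least 3.3-fold lower number from compound 2 to compound 3 (0.52 log units; beyond the scatter). For compound 3 the estimate is 30000 nM, with an expected range of 5000 nM to 100000 nM.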

Compound 3, concentration for 50% growth inhibition: 9500 nM
Estimate against measurement, compound 3: 3.2-fold (0.50 log units) above; measured number inside the range.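

On the aromatic carbon para to a large group, a single halogen swap alone moves the read-out in this assay, with bromo in place of fluoro giving an at least 10-fold lower number from compound 2 to compound 3 (1.02 log units; beyond the scatter). With the second chlorine gone, activity need not be lost, since 4-bromophenyl and 2,4-dichlorophenyl are not separated: a 1.9-fold higher number from compound 1 to compound 3 (0.28 log units; within the scatter). Compound 2 stands at a limit of the assay and not at a number, so the true size of the halogen step stays unread: the limit of > 100000 nM in this assay, at which 1 of the 3 values shown sits.

Open, from the compounds shown here alone, is what chloro, methoxy or an amine would give on this carbon. Also open, going by these compounds, is whether a second halogen adds anything to bromo.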